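Swapping the Aromatic Group at a Saturated Ring Carbon

The source may report more compounds than this note shows. Statements on the series, on what has been measured and on what is new or still open speak of the compounds shown alone.

Compound 1 `O=C(O)CC/C=C\CC1COC(c2cccnc2)OC1c1cccnc1` gives 220 nM in an assay for inhibition of Thromboxane-A synthase (Homo sapiens), using microsomes; on this read-out higher numbers stand for weaker inhibition and lower numbers for stronger inhibition. For the measured compounds named here, compound 2 `O=C(O)CC/C=C\CC1COC(c2cccs2)OC1c1cccnc1` gives 71 nM in this assay, the lowest of the two numbers so far; the change behind that was a 3.1-fold lower number from compound 1 to compound 2 (0.49 log units; beyond the scatter). Compound 3 `O=C(O)CC/C=C\CC1COC(c2ccc3ccccc3c2)OC1c1cccnc1` has not been measured yet; it differs from compound 2 by naphthalen-2-yl in place of thiophen-2-yl on a saturated ring carbon. Going by the values given here, the single measured step, a 3.1-fold lower number from compound 1 to compound 2 (0.49 log units; beyond the scatter), swapped a different aromatic group at the same carbon, so it bears on this new change only loosely. For compound 3 a step of a 1.4-fold higher number from compound 2 to compound 3 (0.15 log units; within the scatter) is expected, with no firm direction. Compound 3 is therefore estimated at 100 nM, ranging from 25 nM to 400 nM.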

Compound 3, half-maximal inhibitory concentration: 50 nM
Estimate against measurement, compound 3: 2.0-fold (0.30 log units) above; low and high end bracket the measured number.
By their numbers in this assay, from the lowest: compounds 3 and 2 (each within the scatter of the next); then compound 1.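

Moving to the larger naphthalen-2-yl, with two six-membered aromatic rings of carbon only and no hydrogen-bond acceptor, makes no real difference at this carbon between the two ring oxygen atoms in this assay: the result is a 1.4-fold lower number from compound 2 to compound 3 (0.15 log units; within the scatter). Replacing pyridin-3-yl with the same group gives a 4.4-fold lower number from compound 1 to compound 3 (0.64 log units; beyond the scatter), so this position accepts two quite different aromatic groups with numbers lower than that of compound 1. Nothing available explains why this is so. Still open, on these data alone, is how a plain phenyl ring or a small methyl group would fare here, and whether an amine on the naphthalen-2-yl group would change the number.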